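The source may hold more compounds than are shown below. What is called first, only, known or untested is meant among the compounds shown, and "the series" means these compounds.

Measured compounds:
- compound 1, `COc1cc(-c2nn(-c3cccc(NC(=O)Nc4cc(C(F)(F)F)cc(C(F)(F)F)c4)c3)cc2-c2ccncc2)ccc1Cl`: 1800 nM
- compound 2, `COc1cc(-c2nn(-c3cccc(NC(=O)c4cccc(C(F)(F)F)c4)c3)cc2-c2ccncc2)ccc1Cl`: 3850 nM

Both numbers come from a functional assay on NCI-H522 cells (Homo sapiens) for inhibition, read by sulforhodamine B assay, with a stated time of 48 h; a higher number here means a weaker inhibitor of growth, a lower number a stronger inhibitor of growth. Compound 2 gives the higher of the two numbers, so among these two it is the weaker inhibitor of growth; compound 1 gives the lower number, and the gap between them lies beyond the scatter.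

Compound 3, `COc1cc(-c2nn(-c3cccc(NC(=O)Nc4ccc(Cl)c(Cl)c4)c3)cc2-c2ccncc2)ccc1Cl`, has not yet been measured in this assay. It differs from compound 2 in one place: (3,4-dichlorophenyl)amino in place of 3-(trifluoromethyl)phenyl on a carbonyl carbon. Put another way, a (3-(trifluoromethyl)phenyl)carbonyl becomes a (3,4-dichlorophenyl)carbamoyl.

Among the compounds with values here, no measured pair maps this exact change, so the expectation rests on the two numbers at hand. Compound 1, which also carries an amino group on its carbonyl carbon, gives 1800 nM, a lower number than compound 2. The step expected from compound 2 to compound 3 is therefore a modest move to a lower number, about a 1.9-fold lower number from compound 2 to compound 3 (0.28 log units; within the scatter), though it may also stay within the scatter. Compound 3 is estimated at 2000 nM, within a range of 800 nM to 5000 nM.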

Compound 3, concentration for total growth inhibition: 3100 nM
Compound 3: middle estimate off by 1.6-fold (0.19 log units), on the low side; the range from low to high includes it.
By their numbers in this assay, from the lowest: compounds 1, 3 and 2 (each within the scatter of the next, the first and the last beyond it).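

In this assay, putting (3,4-dichlorophenyl)amino in place of 3-(trifluoromethyl)phenyl on the carbonyl carbon gives a 1.2-fold lower number from compound 2 to compound 3 (0.09 log units; within the scatter), so this change leaves the reading effectively unchanged, even though the entering group brings a hydrogen-bond donor and the leaving group has none. Before this result, compound 1 at 1800 nM and compound 2 at 3850 nM left open the reading that an amino group on the carbonyl carbon is enough to give the lower number, but compound 3 also carries an amino group there and its 3100 nM lies within the scatter of both, so the amino group alone does not settle the matter. Nothing available here gives a measured reason for this outcome.

The amino group and the ring substituents change together from compound 2 to compound 3, so the compounds shown cannot separate their contributions. Going by these compounds, it also remains open how this carbonyl position would respond to a different kind of group, such as a morpholine, a carboxylic acid or a longer carbon chain carrying the ring.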